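A few compounds are considered here, and "the series" means these few. Any claim that something is new, unique, unknown or untested is made for them only; others in the source may bear on it.

Working notes on a small set of imidazole ethers tested for cytotoxicity in an ADME assay on J774.A1 cells (Mus musculus) for cytotoxicity, read by MTT assay; a higher number here means that more compound is tolerated, a lower number that less compound is tolerated. Of the compounds shown here, three have numbers so far. Compound 1 `Clc1ccc(Cl)c(CO[C@H]2CCc3ccccc3[C@@H]2n2ccnc2)c1` gives 22.3 ug/mL. Compound 2 `Clc1cccc(CO[C@H]2CCc3ccccc3[C@@H]2n2ccnc2)c1` gives 15.5 ug/mL. Compound 3 `Clc1cccc(CO[C@H]2CCCC[C@@H]2n2ccnc2)c1` gives 12.8 ug/mL, which is the lowest of the three, but its gaps to compound 2 and to compound 1 both fall within the scatter, so no order is read from them.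

Compounds 1 and 2 share one core; compound 3 carries a different core, and the difference between the two cores is not broken down here. Among the compounds with values here, the one step that can be counted within the set is a 1.4-fold higher number from compound 2 to compound 1 (0.16 log units; within the scatter), brought about by chloro in place of hydrogen on an aromatic carbon.

Compound 4 `Clc1ccc(Cl)c(CO[C@H]2CCCC[C@@H]2n2ccnc2)c1` is not yet measured in this assay. It stands to compound 3 as compound 1 stands to compound 2: the change is chloro in place of hydrogen on an aromatic carbon, the same change, at the same place, on the other core. The measured step between compound 2 and compound 1 lay within the scatter, so the same change on the core of compound 3 is expected to produce a step of comparable size, a 1.3-fold higher number from compound 3 to compound 4 (0.12 log units; within the scatter), the expectation resting on compound 3 at 12.8 ug/mL and on the earlier step of a 1.4-fold higher number from compound 2 to compound 1 (0.16 log units; within the scatter). Compound 4 is therefore estimated at 17 ug/mL in this assay, with a range of 10 ug/mL to 30 ug/mL allowing for the usual spread of repeated measurements. The measured value will show whether the second core follows the first.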

Compound 4, half-maximal cytotoxic concentration: 27.2 ug/mL
Compound 4: the middle estimate sits 1.6-fold (0.20 log units) below what was measured; low and high end bracket the measured number.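

In this assay chloro in place of hydrogen on an aromatic carbon gives a 2.1-fold higher number from compound 3 to compound 4 (0.33 log units; beyond the scatter) on the core of compound 3, a modest step that stands clear of the scatter. Set beside the earlier step, the two do not differ by more than the scatter of two such steps: the same change on two cores in this assay, a 1.4-fold higher number (0.16 log units; within the scatter) from compound 2 to compound 1 and a 2.1-fold higher number (0.33 log units; beyond the scatter) from compound 3 to compound 4, 1.5-fold (0.17 log units) apart, within the scatter of two such steps. Within the data shown here, the change can therefore be carried between these two cores with a step of comparable size, but this rests on one pair per core, and since only the step on the core of compound 3 lies beyond the scatter, the pairs do not show that the change has a clear effect on both cores, nor that a similar step would appear on any other core.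

The compounds shown leave open whether a group other than chloro at this place, such as methyl, methoxy, an amine or a carboxylic acid, would give a step of similar size and direction. They also leave open how a longer chain in place of the benzylic carbon of the ether would bear on the number in this assay on either core.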